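A ring-to-chain swap on the side chain of compound 1

The compounds below may be only part of what the source reports. "The series", "measured", "known", "first", "only" and "open" are said of these compounds alone.

Compound 1 `COC1=C[C@H](O)[C@H](C/C=C(\C)CC/C=C(\C)C[C@@H]2C[C@@H](C)C(=O)O2)[C@@H](C)C1=O` was tested in a functional assay on PC-3 cells (Homo sapiens) for inhibition, read by sulforhodamine B assay, with a stated time of 48 h; on this read-out lower numbers stand for stronger inhibition of growth and higher numbers for weaker inhibition of growth. In this assay compound 1 reaches only the limit > 30000 nM, so no number is known for it. Compound 2 `COC1=C(OC)[C@H](O)[C@H](C/C=C(\C)CC/C=C(\C)C[C@@H]2C[C@@H](C)C(=O)O2)[C@@H](C)C1=O` likewise gives in this assay only the limit > 30000 nM. Compound 3 `COC1=C(OC)[C@H](O)[C@H](C/C=C(\C)CC/C=C(\C)CCC=C(C)C)[C@@H](C)C1=O` gives 13500 nM in this assay. The step that the two limits leave unreadable from compound 1 to compound 2 cannot be sized because both compounds sit at the limit of > 30000 nM in this assay, at which 2 of the 3 values shown sit. Among the compounds with values here, the step of an at least 2.2-fold lower number from compound 2 to compound 3 (0.34 log units; beyond the scatter) is the one readable change at the end of the side chain.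

Compound 4 `COC1=C[C@H](O)[C@H](C/C=C(\C)CC/C=C(\C)C[C@H](O)/C=C(\C)CO)[C@@H](C)C1=O` differs from compound 1 by a group of 7 heavy atoms (5 carbon, 2 oxygen; no ring) in place of a group of 7 heavy atoms (5 carbon, 2 oxygen; one five-membered non-aromatic ring with 1 hetero atom), on a saturated chain carbon bound to a double-bonded chain carbon. Of the measured steps, only an at least 2.2-fold lower number from compound 2 to compound 3 (0.34 log units; beyond the scatter) bears on this position, and it also removed the five-membered ring with its hetero atom from that carbon; compound 4 keeps two oxygen atoms in the new group, so the match is loose. Compound 1 stands at a limit, which makes its starting point itself uncertain. The account expects the step of an at least 1.5-fold lower number from compound 1 to compound 4 (0.17 log units; that floor lies within the scatter), a moderate move toward stronger inhibition in this assay. Compound 4 is therefore estimated at 20000 nM in this assay, with a range of 6000 nM to 60000 nM.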

Compound 4, concentration for 50% growth inhibition: > 30000 nM
Compound 4 gave a limit, no number (the forecaster's own chance of this, stated with the estimate: 45%); at least 1.5-fold (0.17 log units) between middle value and limit.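

In this assay, compound 4 yields only a limit, as compound 1 does, so no step can be read between them, because both compounds sit at the same point: the limit of > 30000 nM in this assay, at which 3 of the 4 values shown sit.

The compounds shown leave open whether the open chain of compound 4, in place of the five-membered ring group of compound 1, changes growth inhibition at all.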